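The compounds below may be only part of what the source reports. "The series", "measured", "known", "first", "only" and "open" are said of these compounds alone.

Measured so far:
compound 1 `COc1cc(NC(=O)Nc2cc(Nc3ccc(C)c(C)c3)ncn2)cc(OC)c1`: 66%
compound 2 `COc1ccc(OC)c(Nc2cc(NC(=O)Nc3c(Cl)cccc3Cl)ncn2)c1`: 95%

In a functional assay on PC-9 cells (Homo sapiens) for inhibition, read by MTT assay, with a stated time of 48 h, tested at 10 uM (a higher number here means more inhibition at the concentration tested (going by the name of the read-out), a lower number less inhibition), compound 1 gives 66%, the lower of the two numbers; compound 2 gives 95%, a number beyond the scatter above it. Compound 3 `COc1cc(NC(=O)Nc2cc(Nc3ccc(OC)c(C)c3)ncn2)cc(OC)c1` is not yet measured. It differs from compound 1 by methoxy in place of methyl on an aromatic carbon. For the measured compounds named here, no measured pair shows this change on its own, so its effect in this assay has to be guessed, and no step beyond the scatter is expected. In this assay compound 3 is expected to give about 65%, within 48% to 82%. The step of a number 1 percentage points lower from compound 1 to compound 3 (within the scatter) is estimated to stay within the scatter.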

Compound 3, a percentage reported as inhibition, at one concentration (the size of the read-out at that concentration, not a potency): 62%
Compound 3: middle estimate off by 3 percentage points, on the high side; measured number inside the range.
By their numbers in this assay, from the lowest: compounds 3 and 1 (each within the scatter of the next); then compound 2.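

In this assay, 3,4-dimethylphenyl to 4-methoxy-3-methylphenyl gives a number 4 percentage points lower from compound 1 to compound 3 (within the scatter) as the series' first pair differing in one place. At this position, para to a large group and ortho to a methyl group, methoxy in place of methyl therefore leaves no step beyond the scatter. Nothing measured here speaks to a cause.

Open, on these data alone, is whether an amine, a carboxylic acid or a longer alkoxy chain such as butoxy at this position would also stay within the scatter of compound 1. As far as these compounds go, the same swap on a different urea partner also remains open.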